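Amino for chloro, second instance on a related core

This account rests on a few compounds, and the source may have more. Where it says the series, first, only, none or still open, it means among the compounds named here.

Measured in a functional assay on PC-3 cells (Homo sapiens) for cytotoxicity, read by sulforhodamine B assay, with a stated time of 48 h (a higher number here means a weaker inhibitor of growth, a lower number a stronger inhibitor of growth), so far:
compound 1 `Nc1nc(Cl)c2ncn(Cc3ccc(CCl)cc3)c2n1` gives 25100 nM
compound 2 `ClCc1cccc(Cn2cnc3c(Cl)nc(Cl)nc32)c1` gives 5010 nM
compound 3 `ClCc1ccc(Cn2cnc3c(Cl)nc(Cl)nc32)cc1` gives 7240 nM

Compound 3 and compound 2 lie within the scatter of each other; compound 1 stands beyond both. From compound 3 to compound 1 the change is amino in place of chloro on an aromatic carbon, and the step is a 3.5-fold higher number from compound 3 to compound 1 (0.54 log units; beyond the scatter). The difference between the cores of compound 2 and compound 3 is not broken down here.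

Compound 4 `Nc1nc(Cl)c2ncn(Cc3cccc(CCl)c3)c2n1` is not yet measured. It differs from compound 2 by amino in place of chloro on an aromatic carbon, the same change as from compound 3 to compound 1, at a place described in the same words. Among the measured compounds shown here, the step from compound 2 to compound 4 is expected to be a 3.4-fold higher number from compound 2 to compound 4 (0.53 log units; beyond the scatter) in this assay, because the one earlier instance gave a 3.5-fold higher number from compound 3 to compound 1 (0.54 log units; beyond the scatter). Compound 4 is therefore estimated at 17000 nM, within 7000 nM to 40000 nM.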

Compound 4, concentration for total growth inhibition: 25100 nM
Estimate against measurement, compound 4: 1.5-fold (0.17 log units) below, within the range that was stated.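

In this assay, amino in place of chloro on an aromatic carbon gives a 5.0-fold higher number from compound 2 to compound 4 (0.70 log units; beyond the scatter) on the second core, and the two instances agree in direction and, within the scatter, in size: the same change on two cores in this assay, a 3.5-fold higher number (0.54 log units; beyond the scatter) from compound 3 to compound 1 and a 5.0-fold higher number (0.70 log units; beyond the scatter) from compound 2 to compound 4, 1.4-fold (0.16 log units) apart, within the scatter of two such steps. In this pair of cores, the step therefore carries over from one to the other. Two instances in one assay do not show that it would hold on a more distant core, and they do not explain why the number rises.

The compounds shown leave open how a methylamine or a hydroxyl group on that carbon would compare with amino and chloro. Also open, going by these compounds, is whether the step survives when the chloromethyl group gives way to a longer chain.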